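This account rests on a few compounds, and the source may have more. Where it says the series, first, only, none or still open, it means among the compounds named here.

In a functional assay for inhibition, with Homo sapiens as the target (a higher number here means that more compound is needed for the effect, a lower number that less compound is needed), three compounds that share a core have been measured. Compound 1 (`CC(=O)Nc1ccc(C2=NNC(=O)CC2)cc1`) gives 1 ug/mL, compound 2 (`CC(Cl)C(=O)Nc1ccc(C2=NNC(=O)CC2)cc1`) gives 0.45 ug/mL, and compound 3 (`CCC(Cl)C(=O)Nc1ccc(C2=NNC(=O)CC2)cc1`) gives 1.47 ug/mL. Compound 3 stands at the high end of these numbers, together with compound 1 within the scatter, and compound 2 lies clearly lower. The next compound is compound 4 (`C=CCNCC(=O)Nc1ccc(C2=NNC(=O)CC2)cc1`), where the change is a group of 5 heavy atoms (4 carbon, 1 nitrogen; no ring) in place of a group of 4 heavy atoms (3 carbon, 1 chlorine; no ring), on a carbonyl carbon. Among the measured compounds shown here, the entering group is (allylamino)methyl, and no measured compound carries a nitrogen-containing group at this place, so the steps offer only loose guidance. Those steps are a 2.2-fold lower number from compound 1 to compound 2 (0.35 log units; beyond the scatter), a 1.5-fold higher number from compound 1 to compound 3 (0.17 log units; within the scatter) and a 3.3-fold higher number from compound 2 to compound 3 (0.51 log units; beyond the scatter). As all three are modest or within the scatter, only a small step in this assay is expected, with no firm direction and probably none beyond the scatter. The estimated step is a 1.3-fold lower number from compound 3 to compound 4 (0.13 log units; within the scatter). For compound 4 the expected value is 1.1 ug/mL, with an estimated range from 0.35 ug/mL to 3.5 ug/mL.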

Compound 4, half-maximal effective concentration: about 21.5 ug/mL
Estimate against measurement, compound 4: 20-fold (1.29 log units) below; measured number outside the range, above it.
By their numbers in this assay, from the lowest: compound 2; then compounds 1 and 3 (each within the scatter of the next); then compound 4.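

In this assay, (allylamino)methyl on the carbonyl carbon brings a 15-fold higher number from compound 3 to compound 4 (1.17 log units; beyond the scatter) and a 48-fold higher number from compound 2 to compound 4 (1.68 log units; beyond the scatter) as well, so this place admits large steps, whereas the methyl and chlorine-bearing chains shown earlier had differed only modestly or within the scatter. Seen as a single addition, allylamino in place of hydrogen on the saturated chain carbon bound to a carbonyl carbon gives a 22-fold higher number from compound 1 to compound 4 (1.33 log units; beyond the scatter) and thus ties the rise to this added group, the only nitrogen-containing one at this place. Nothing measured here explains the rise.

The compounds shown leave open whether the nitrogen or the allyl part goes with the higher number. A plain aminomethyl, a propylaminomethyl or a methoxymethyl group at this place would separate the two.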